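A few compounds are considered here, and "the series" means these few. Any claim that something is new, unique, unknown or untested is made for them only; others in the source may bear on it.

Among the three compounds measured in an assay on cell membranes for displacement of a labelled ligand from corticotropin-releasing factor receptor 1 (Rattus norvegicus) (a higher number here means a weaker inhibitor, a lower number a stronger inhibitor), compound 1 `CCC(CC)Nc1nc(C)nc2c(-c3cc(F)c(OC)cc3Cl)c(C)nn12` stands lowest with 1 nM. Compound 3 `CCC(CC)Nc1nc(C)nc2c(-c3cc(F)c(OC)cc3C)c(C)nn12` gives 1.9 nM, and the step of a 1.9-fold higher number from compound 1 to compound 3 (0.28 log units; within the scatter) stays within the scatter. Compound 2 `CCCN(C)c1nc(C)nc2c(-c3c(C)cc(OC)cc3OC)c(C)nn12` gives 6.48 nM, a higher number than compound 1 beyond the scatter, but it differs from compound 1 in both its aryl ring and its amino group, so no single change separates the two. Compound 4 `CCN(CC)c1nc(C)nc2c(-c3cc(F)c(OC)cc3Cl)c(C)nn12` differs from compound 1 by diethylamino in place of (pentan-3-yl)amino on an aromatic carbon. Among the compounds with values here, no measured step touches the amino group alone, so the expectation rests on the general closeness of these numbers. The estimate for compound 4 in this assay is 3 nM, expected to fall between 0.8 nM and 12 nM. This estimate means an expected step of a 3.0-fold higher number from compound 1 to compound 4 (0.48 log units; beyond the scatter).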

Compound 4, half-maximal inhibitory concentration: 1.64 nM
Beside the measured number, compound 4's estimate is 1.8-fold (0.26 log units) above it; the measured number falls inside the stated range.
By their numbers in this assay, from the lowest: compounds 1, 4 and 3 (each within the scatter of the next); then compound 2.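

In this assay, diethylamino in place of (pentan-3-yl)amino gives a 1.6-fold higher number from compound 1 to compound 4 (0.21 log units; within the scatter), the first step shown that changes the amino group alone. At this aromatic carbon, between two ring nitrogen atoms, a group with 0 hydrogen-bond donors therefore reads the same, within the scatter, as one with 1 hydrogen-bond donor. No measurement available here explains this result. Still open, as far as these compounds go, is how a ring amine such as morpholine or a longer chain such as dipropylamino would fare at this position.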